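A few compounds are considered here, and "the series" means these few. Any claim that something is new, unique, unknown or untested is made for them only; others in the source may bear on it.

Compound 1, `CCn1c(/C=C2/C(=O)Nc3ccc(C)cc32)nc2ccccc21`, was tested in a functional assay on MCF7 cells (Homo sapiens) for cytotoxicity, read by MTT assay, with a stated time of 48 h; on this read-out lower numbers stand for stronger inhibition and higher numbers for weaker inhibition. In this assay compound 1 gives > 50000 nM, which is a limit of the assay and not a number. Compound 2, `Cn1c(/C=C2/C(=O)Nc3ccc([N+](=O)[O-])cc32)nc2ccccc21`, stands differently: for compound 2 this assay reports "not determined" (no result reported), so there is no single number to place it against. Going by the values given here, of the two values shown, one is a limit; the evidence on the measured compounds amounts to the limit of > 50000 nM in this assay, at which 1 of the 2 values shown sits, and no step between measured compounds can be drawn from it.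

Compound 3, `Cn1c(/C=C2/C(=O)Nc3ccc(F)cc32)nc2ccccc21`, has not yet been measured. Compared with compound 2 the change is fluoro in place of nitro on an aromatic carbon. Among the compounds with values here, with no number for compound 2, no step can be expected in this assay from compound 2 to compound 3, neither upward nor downward beyond the scatter; the only guide is that compound 1 sits at a limit. Compound 3 is therefore expected to land near that limit, estimated at about 45000 nM, with a range from 10000 nM to 100000 nM.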

Compound 3, half-maximal inhibitory concentration: 31600 nM
Estimate against measurement, compound 3: 1.4-fold (0.15 log units) above; the measured number falls inside the stated range.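

Compound 3 gives 31600 nM in this assay, but no step can be read from this result: compound 2 has no number to compare it with, and compound 1 differs from compound 3 in more than one place. The compounds shown leave open how replacing nitro with fluoro on that aromatic carbon changes the value in this assay.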